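Adding an Amino Group to the Chain of Compound 2

The source may report more compounds than this note shows. Statements on the series, on what has been measured and on what is new or still open speak of the compounds shown alone.

Measured compounds:
compound 1, `CCCCCCCCCCc1ccc(-c2noc(C3CNC3)n2)cc1`, 65%
compound 2, `CCCCCCCCCCc1ccc(-c2noc(CCCN)n2)cc1`, 67%
compound 3, `CCCCCCCCCCc1ccc(-c2noc(C3CCNC3)n2)cc1`, 26%

In an assay on HeLa cells for inhibition of sphingosine-1-phosphate transporter SPNS2 (Mus musculus), read by LC-MS, tested at 2 uM (a lower number here means less inhibition, a higher number more inhibition at the concentration tested (going by the name of the read-out)), compound 2 gives the highest of the three numbers. Its nearest neighbour is compound 1, and the step of a number 2 percentage points higher from compound 1 to compound 2 (within the scatter) lies within the scatter, so the two cannot be ordered. Compound 3 stands furthest away: the step of a number 41 percentage points lower from compound 2 to compound 3 (beyond the scatter) is large, as is a number 39 percentage points lower from compound 1 to compound 3 (beyond the scatter).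

Compound 4, `CCCCCCCCCCc1ccc(-c2noc([C@@H](N)CCN)n2)cc1`, has not been measured. It differs from compound 2 by amino in place of hydrogen on a saturated chain carbon bound to an aromatic carbon and a saturated chain carbon. The chain itself is kept; only a hydrogen on it is exchanged.

Among the measured compounds shown here, none of the measured steps mirrors this change. The two large steps both exchange an open chain or a small ring for pyrrolidin-3-yl, and the step within the scatter exchanges azetidin-3-yl for 3-aminopropyl. For the measured compounds named here, no step shows what adding an amino group to a chain that is otherwise retained does. On that basis compound 4 is expected to stay near compound 2, with no step beyond the scatter in either direction, but with a wide range of uncertainty. The expected step is a number 7 percentage points lower from compound 2 to compound 4 (within the scatter). For compound 4 the estimate in this assay is 60%, between 35% and 85%.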

Compound 4, a percentage reported as inhibition, at one concentration (the size of the read-out at that concentration, not a potency): 14%
Compound 4: the middle estimate sits 46 percentage points above what was measured; the measured number lies below the stated range.
By their numbers in this assay, from the lowest: compound 4; then compound 3; then compounds 1 and 2 (each within the scatter of the next).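

On the saturated chain carbon bound to an aromatic carbon and a saturated chain carbon, amino in place of hydrogen proved to be a large change in this assay (a number 53 percentage points lower from compound 2 to compound 4 (beyond the scatter)), even though the rest of the 3-aminopropyl chain is kept. The earlier compounds had shown large steps only where pyrrolidin-3-yl entered, but 1,3-diaminopropyl also stands far from azetidin-3-yl (a number 51 percentage points lower from compound 1 to compound 4 (beyond the scatter)) and goes modestly past pyrrolidin-3-yl itself (a number 12 percentage points lower from compound 3 to compound 4 (beyond the scatter)). An open chain therefore does not by itself hold the number seen for compound 2, and one added amino group on this carbon is enough to lose it, leaving compound 4 lowest of the four.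

On these data alone, it remains open whether the fall belongs to the amino group as such or to its particular spatial arrangement, and the mirror-image form of compound 4, or a hydroxyl or methyl group on the same carbon, would help separate these. Nothing in the available data bears on why the number falls.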